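The compounds below may be only part of what the source reports. "The series", "measured", "known", "first", "only" and "open" are said of these compounds alone.

Compound 3, whose structure is `CCCCCCCCCCCCCCCCCCNC(=O)[C@@H](NC(=O)c1cc2ccccc2[nH]1)[C@@H](C)O`, is one of three compounds characterised in a functional assay on HepG2 cells (Homo sapiens) for cytotoxicity, read by MTT assay, with a stated time of 48 h; on this read-out higher numbers stand for weaker inhibition and lower numbers for stronger inhibition. Compound 2, with the structure `CCCCCCCCCCCCCCCCCCNC(=O)[C@@H](NC(=O)c1nccc2ccccc12)[C@@H](C)O`, gives 96900 nM in this assay. Compound 3 gives 89400 nM in this assay, the lowest of the two numbers shown, although the step of a 1.1-fold lower number from compound 2 to compound 3 (0.03 log units; within the scatter) is within the scatter, so no order between compound 2 and compound 3 can be read from it. Compound 1, with the structure `C/C=C/C=C/C(=O)N[C@H](C(=O)NCCCCCCCCCCCC)[C@@H](C)O`, reaches only a limit of this assay, > 400000 nM; the evidence for it is the limit of > 400000 nM in this assay, at which 1 of the 3 values shown sits.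

Compound 4, whose structure is `C/C=C/C=C/C(=O)N[C@H](C(=O)NCCCCCCCCCCCCCCCCCC)[C@@H](C)O`, differs from compound 3 in that (penta-1,3-dien-1-yl in place of 1H-indol-2-yl on a carbonyl carbon). For the measured compounds named here, the only measured step, from compound 2 to compound 3, exchanges one ring system for another and is within the scatter, so it does not bear on a change from a ring system to an open chain. Compound 1 carries the same penta-1,3-dien-1-yl group on a shorter chain and reaches only the limit of this assay, which points to a higher number for compound 4. The expected step is therefore a 3.4-fold higher number from compound 3 to compound 4 (0.53 log units; beyond the scatter), and compound 4 is estimated at 300000 nM, with a range from 100000 nM to 800000 nM.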

Compound 4, half-maximal inhibitory concentration: 284000 nM
Compound 4: middle estimate off by 1.1-fold (0.02 log units), on the high side; the range from low to high includes it.
By their numbers in this assay, from the lowest: compounds 3 and 2 (each within the scatter of the next); then compound 4. At a limit, above all of these: compound 1.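

For the compounds shown here, on the carbonyl carbon whose other neighbour is the amide-type nitrogen, this change gives the first steps at this place that lie beyond the scatter in this assay, a 3.2-fold higher number from compound 3 to compound 4 (0.50 log units; beyond the scatter) and a 2.9-fold higher number from compound 2 to compound 4 (0.47 log units; beyond the scatter), so the open penta-1,3-dien-1-yl group stands modestly higher than both ring-bearing groups. The step on the saturated chain, an at least 1.4-fold lower number from compound 1 to compound 4 (0.14 log units; that floor lies within the scatter), has a floor within the scatter, so it does not establish what the added hexyl does. Compound 1 remains a limit of the assay: the limit of > 400000 nM in this assay, at which 1 of the 4 values shown sits.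

On these data alone, whether a phenyl group or a saturated pentyl group on that carbonyl carbon would fall with the ring-bearing compounds or with compound 4 remains open. So does the effect of an amine or a carboxylic acid on the saturated chain.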